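Removing the acetyl from compound 2: an amino analogue

The compounds below may be only part of what the source reports. "The series", "measured", "known", "first", "only" and "open" are said of these compounds alone.

Compound 1 `NC(=O)c1cc(-c2ccc3nc(NC(=O)C4CC4)sc3c2)cc(NS(=O)(=O)c2ccc(F)cc2)c1Cl` gives 11400 nM in a functional assay on HCT-116 cells (Homo sapiens) for antiproliferative activity, read by MTT assay, with a stated time of 72 h; on this read-out lower numbers stand for stronger inhibition and higher numbers for weaker inhibition.
Compound 2 `COc1c(NS(=O)(=O)c2ccc(F)cc2)cc(-c2ccn3nc(NC(C)=O)nc3c2)cc1C(N)=O` gives 32600 nM in this assay.

Among the compounds with values here, of the two measured compounds, compound 2 stands at the higher, weaker end in this assay; its only neighbour, compound 1, sits at a lower number, and the gap between them lies beyond the usual scatter. The two compounds share no single-point difference, so nothing beyond their own two values can be drawn from them.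

Compound 3 `COc1c(NS(=O)(=O)c2ccc(F)cc2)cc(-c2ccn3nc(N)nc3c2)cc1C(N)=O` is the unmeasured analogue of compound 2. The change is hydrogen in place of acetyl on a nitrogen on an aromatic ring. Within the data shown here, no measured pair shows this change, so the direction of the step rests on expectation only. The step from compound 2 to compound 3 is expected to be a 1.4-fold higher number from compound 2 to compound 3 (0.14 log units; within the scatter), a modest move toward weaker inhibition. Compound 3 is therefore estimated at 45000 nM in this assay, with a range from 12000 nM to 150000 nM.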

Compound 3, half-maximal inhibitory concentration: > 50000 nM
Compound 3: a limit, no number (the forecaster's own chance of this, stated with the estimate: 25%); middle value at least 1.1-fold (0.04 log units) from the limit.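

Compound 3 gives a limit and not a number in this assay, so the value of the amino analogue is bounded on one side only: the limit of > 50000 nM in this assay, at which 1 of the 3 values shown sits. Within the data shown here, the change from acetamido to amino on this nitrogen is the first single-point step available here, and it reads as an at least 1.5-fold higher number from compound 2 to compound 3 (0.18 log units; that floor lies within the scatter), a floor and not a size, so the real step could be larger than the scatter or could stay within it. What it does show is that removing the acetyl at this place brought no readable gain in inhibition.

On these data alone, how far compound 3 lies beyond its limit stays open, and with it the true size of the step. Also open, as far as these compounds go, is whether a longer acyl chain or a methyl group on this nitrogen would give a lower number than compound 2 in this assay.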